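The source may hold more compounds than are shown below. What is called first, only, known or untested is meant among the compounds shown, and "the series" means these compounds.

Compound 2 `CN1CCN(c2ccc(Nc3ncc4nc(Sc5ccccc5)n(C5CCCC5)c4n3)cc2)CC1` is the starting point of this step. Among the compounds with values here, in a functional assay on HCC827 cells (Homo sapiens) for antiproliferative activity, read by MTT assay, with a stated time of 72 h (a lower number here means a stronger inhibitor, a higher number a weaker inhibitor), compound 2 gives 51.2 nM, which is the second highest of the three numbers measured so far. Its nearest neighbour is compound 1 `CN1CCN(c2ccc(Nc3ncc4nc(Sc5ccccc5)n(C5CCOCC5)c4n3)cc2)CC1`, for which this assay gives 42.6 nM; its furthest is compound 3 `CN1CCN(c2ccc(Nc3ncc4nc([S+]([O-])Cc5cccnc5)n(C5CCCC5)c4n3)cc2)CC1`, for which this assay gives 2350 nM.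

Two measured steps are available. The step of a 1.2-fold higher number from compound 1 to compound 2 (0.08 log units; within the scatter) also alters the group on the aromatic nitrogen and is therefore the one that bears on the present change. The step of a 46-fold higher number from compound 2 to compound 3 (1.66 log units; beyond the scatter) concerns a different part of the shared core and does not bear on it.

Compound 4 `CN1CCN(c2ccc(Nc3ncc4nc(Sc5ccccc5)n(C5CC5)c4n3)cc2)CC1` differs from compound 2 in cyclopropyl in place of cyclopentyl on an aromatic nitrogen. Within the data shown here, the one comparable change, from compound 1 to compound 2, stayed within the scatter, so a change of ring size at this position is expected to give, at most, a small step in this assay, and no direction can be argued from the data. Compound 4 is therefore estimated at 70 nM, within a range of 25 nM to 200 nM, which would correspond to an expected step of a 1.4-fold higher number from compound 2 to compound 4 (0.14 log units; within the scatter).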

Compound 4, half-maximal inhibitory concentration: 305 nM
For compound 4 the middle estimate is 4.4-fold (0.64 log units) below the measured one; the measured number lies above the stated range.
By their numbers in this assay, from the lowest: compounds 1 and 2 (each within the scatter of the next); then compound 4; then compound 3.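

In this assay, within the data shown here, the group on the aromatic nitrogen proves able to shift the number well beyond the scatter: cyclopropyl in place of cyclopentyl gives a 6.0-fold higher number from compound 2 to compound 4 (0.78 log units; beyond the scatter), and cyclopropyl in place of oxan-4-yl gives a 7.2-fold higher number from compound 1 to compound 4 (0.85 log units; beyond the scatter), whereas the only earlier change here, a 1.2-fold higher number from compound 1 to compound 2 (0.08 log units; within the scatter), stayed within it. Among the three compounds that carry the phenylsulfanyl group, compound 1 and compound 2 remain level and only compound 4, with its three-membered ring, stands apart, so the change of cyclopentyl to oxan-4-yl says little about how far this position tolerates other groups. No measurement at hand accounts for this step.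

The compounds shown leave open whether the weaker result belongs to the cyclopropyl ring itself or to the smaller number of heavy atoms, a question that cyclobutyl or an open chain such as isopropyl on the same nitrogen would address. They also leave open how a ring carrying an amine, such as piperidin-4-yl, would behave here, and whether the step from cyclopentyl to cyclopropyl would be the same size with a different group on the aromatic carbon.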